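Phenethyl Thioether in Place of the Methoxybenzyl Group

The source may report more compounds than this note shows. Statements on the series, on what has been measured and on what is new or still open speak of the compounds shown alone.

Compound 3 `COc1ccc(CSc2nc(C(F)(F)F)ccc2CNC(=O)C(C)c2ccc(NS(C)(=O)=O)c(F)c2)cc1` stands second highest of the three numbers in an assay on CHO-K1 cells for antagonist activity at transient receptor potential cation channel subfamily V member 1 (Homo sapiens), read by FLIPR (on this read-out higher numbers stand for weaker inhibition and lower numbers for stronger inhibition), giving 2.3 nM; compound 1 `CC(C)CCSc1nc(C(F)(F)F)ccc1CNC(=O)C(C)c1ccc(NS(C)(=O)=O)c(F)c1` gives 0.7 nM and compound 2 `COC(=O)CCSc1nc(C(F)(F)F)ccc1CNC(=O)C(C)c1ccc(NS(C)(=O)=O)c(F)c1` gives 48.2 nM. Compound 4 `CC(C(=O)NCc1ccc(C(F)(F)F)nc1SCCc1ccccc1)c1ccc(NS(C)(=O)=O)c(F)c1` differs from compound 3 by benzyl in place of 4-methoxyphenyl on a saturated chain carbon bound to a sulfur. Going by the values given here, two measured steps bear on this change: a 3.3-fold higher number from compound 1 to compound 3 (0.52 log units; beyond the scatter), a modest one, and a 21-fold lower number from compound 2 to compound 3 (1.32 log units; beyond the scatter), a large one. In both, the compound carrying an aryl or alkyl group at this carbon sits low and only compound 2, carrying the methoxycarbonyl, sits high. With the methoxy gone and a methylene entering, compound 4 is expected to stay close to compound 3, a step of a 1.5-fold lower number from compound 3 to compound 4 (0.19 log units; within the scatter) that lies within the scatter. The estimate for compound 4 is 1.5 nM, ranging from 0.5 nM to 5 nM.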

Compound 4, inhibition constant: 1.9 nM
Estimate against measurement, compound 4: 1.3-fold (0.10 log units) below; the measured number falls inside the stated range.
By their numbers in this assay, from the lowest: compound 1; then compounds 4 and 3 (each within the scatter of the next); then compound 2.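

In this assay, the phenethyl thioether of compound 4 does as well as the 4-methoxybenzyl thioether (a 1.2-fold lower number from compound 3 to compound 4 (0.08 log units; within the scatter)), so benzyl can replace 4-methoxyphenyl on this carbon without a change beyond the scatter. Phenyl in place of methoxycarbonyl gives a large gain (a 25-fold lower number from compound 2 to compound 4 (1.40 log units; beyond the scatter)), whereas phenyl in place of isopropyl gives a modest loss (a 2.7-fold higher number from compound 1 to compound 4 (0.43 log units; beyond the scatter)), so this aromatic ring does not match the isopropyl end of compound 1. Nothing available explains these differences. As far as these compounds go, whether a longer chain ending in phenyl, or an amine at the chain end, would sit nearer compound 1 or compound 2 remains open.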